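The compounds below may be only part of what the source reports. "The series", "measured", "known", "first", "only" and "open" are said of these compounds alone.

Measured so far:
compound 1, `Cc1cnc(Nc2ccc(C(C)C)cc2)nc1Nc1nc2ccccc2s1`, in a functional assay on MCF7 cells (Homo sapiens) for antiproliferative activity, read by MTT assay, with a stated time of 48 h (a higher number here means a weaker inhibitor, a lower number a stronger inhibitor), compound 1 gives > 50000 nM
compound 2, `Cc1cnc(Nc2ccc(Cl)cc2)nc1Nc1nc2ccccc2s1`, in this assay compound 2 gives > 50000 nM

The value of compound 1 in this assay is a limit of the assay and not a number. The value of compound 2 in this assay is likewise a limit and not a number. Compound 2 therefore stands at the limit, and the step that the two limits leave unreadable from compound 1 to compound 2 cannot be read because the limit of > 50000 nM in this assay, at which 2 of the 2 values shown sit, covers both ends of it. With chloro in place of isopropyl on an aromatic carbon nothing measurable changes within what the assay can report.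

Compound 3, `COc1cccc(Nc2ncc(C)c(Nc3nc4ccccc4s3)n2)c1`, differs from compound 2 by 3-methoxyphenyl in place of 4-chlorophenyl on a nitrogen on an aromatic ring. Among the measured compounds shown here, no measured step bears on this change with a readable size; the only guide is that both measured compounds sit at the limit. The step that the limit leaves unreadable from compound 2 to compound 3 is therefore expected to be none beyond the scatter, with the result most likely again reported only as a limit. Compound 3 is expected to give about 80000 nM in this assay, within the range 15000 nM to 400000 nM.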

Compound 3, half-maximal inhibitory concentration: > 50000 nM
Compound 3 gave a limit, no number; the forecaster's own chance of this, stated with the estimate: 80%; the middle value lies beyond the limit too.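

In this assay compound 3 gives > 50000 nM, a limit of the assay and not a number. No step among compound 1, compound 2 and compound 3 can be read, because all three stand at the same limit: the limit of > 50000 nM in this assay, at which 3 of the 3 values shown sit.

The compounds shown leave open whether any group on that nitrogen on an aromatic ring gives a readable value in this assay.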